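Working notes: trifluoromethyl-to-fluoro swaps in a cytotoxicity series

This account rests on a few compounds, and the source may have more. Where it says the series, first, only, none or still open, it means among the compounds named here.

Measured so far, in a functional assay on QGY-7703 cells (Homo sapiens) for cytotoxicity, read by MTT assay, with a stated time of 24 h; on this read-out higher numbers stand for weaker inhibition and lower numbers for stronger inhibition:
compound 1 `CN1C/C(=C\c2cccnc2)C(=O)/C(=C/c2ccccc2F)C1`: 4470 nM
compound 2 `CN1C/C(=C\c2cccnc2)C(=O)/C(=C/c2ccccc2C(F)(F)F)C1`: 2910 nM
compound 3 `O=C1/C(=C/c2ccncc2)CN(S(=O)(=O)c2ccc(C(F)(F)F)cc2)C/C1=C\c1ccccc1C(F)(F)F`: 4680 nM

Compound 2 and compound 1 differ by fluoro in place of trifluoromethyl on an aromatic carbon, and a 1.5-fold higher number from compound 2 to compound 1 (0.19 log units; within the scatter). Compound 4 `O=C1/C(=C/c2ccncc2)CN(S(=O)(=O)c2ccc(F)cc2)C/C1=C\c1ccccc1C(F)(F)F` is not yet measured; it differs from compound 3 by fluoro in place of trifluoromethyl on an aromatic carbon. Around the place the two changes are not identical: in compound 1 the fluoro sits ortho to a large group, in compound 4 para to a large group, so this is the same kind of change rather than the same change. How the core of compound 3 differs from that of compound 2 is not broken down here; the two numbers, compound 3 at 4680 nM and compound 2 at 2910 nM, lie within the scatter of each other.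

For compound 4 in this assay a step like the earlier one is expected, a 1.3-fold higher number from compound 3 to compound 4 (0.12 log units; within the scatter), resting on compound 2 to compound 1 giving a 1.5-fold higher number from compound 2 to compound 1 (0.19 log units; within the scatter). The estimate for compound 4 is 6200 nM, expected between 2600 nM and 15000 nM.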

Compound 4, half-maximal inhibitory concentration: 7700 nM
Compound 4: the middle estimate sits 1.2-fold (0.09 log units) below what was measured; the range from low to high includes it.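

In this assay, fluoro in place of trifluoromethyl gives a 1.6-fold higher number from compound 3 to compound 4 (0.22 log units; within the scatter), and set beside the earlier step the change carries across the two cores without a detectable difference: the same change on two cores in this assay, a 1.5-fold higher number (0.19 log units; within the scatter) from compound 2 to compound 1 and a 1.6-fold higher number (0.22 log units; within the scatter) from compound 3 to compound 4, 1.1-fold (0.03 log units) apart, within the scatter of two such steps. Within the data shown here, both steps are small, so the agreement shows only that the swap stayed within the scatter on each core, not that it has a real effect on either. Nor do two pairs establish a rule for the series, and the two swaps do not stand in identical surroundings.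

Still open, as far as these compounds go, is whether a different group at these places, such as an amine, a nitrile or a carboxylic acid, would give a step beyond the scatter. Other cores also remain untested in the compounds shown.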